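The compounds below may be only part of what the source reports. "The series", "measured", "known", "first", "only" and "open" are said of these compounds alone.

Measured compounds:
compound 1, `COc1cccc(NC(=O)CSc2nc(Nc3ccccc3)c3ccccc3n2)c1`, gives 21700 nM in a functional assay on MDA-MB-231 cells (Homo sapiens) for inhibition, read by MTT assay, with a stated time of 72 h; a lower number here means a stronger inhibitor, a higher number a weaker inhibitor
compound 2, `C=CC(=O)Nc1cccc(NC(=O)CSc2nc(Nc3cccc(Br)c3)c3ccccc3n2)c1`, gives 19400 nM in this assay

Compound 2 and compound 1 lie within the scatter of each other in this assay; the two numbers show no separation. Compound 3, `C=CC(=O)Nc1cccc(NC(=O)CSc2nc(Nc3ccc(C(F)(F)F)cc3)c3ccccc3n2)c1`, is not yet measured. It differs from compound 2 by 4-(trifluoromethyl)phenyl in place of 3-bromophenyl on a nitrogen on an aromatic ring. Going by the values given here, no measured pair speaks to this change, so the expected step in this assay is a 1.0-fold higher number from compound 2 to compound 3 (0.01 log units; within the scatter), none beyond the scatter. Compound 3 is estimated at 20000 nM, with a range from 8000 nM to 50000 nM.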

Compound 3, half-maximal inhibitory concentration: 11500 nM
Beside the measured number, compound 3's estimate is 1.7-fold (0.24 log units) above it; measured number inside the range.
By their numbers in this assay, from the lowest: compounds 3, 2 and 1 (each within the scatter of the next).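

In this assay, 4-(trifluoromethyl)phenyl in place of 3-bromophenyl on the nitrogen gives a 1.7-fold lower number from compound 2 to compound 3 (0.23 log units; within the scatter). Going by these compounds alone, this is the first single-place step, and at this position the two groups do not separate beyond the scatter. No measurement shown bears on the reason for this result.

As far as these compounds go, it remains open whether a different kind of group on this phenyl ring, such as an amine or a carboxylic acid, would move the number beyond the scatter. A single step also cannot define a trend at this position.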